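The source may hold more compounds than are shown below. What is called first, only, known or untested is meant among the compounds shown, and "the series" means these compounds.

Measured compounds:
Compound 1 `Cc1c(C)c2ccc(OC[C@@H](O)c3ccccc3)cc2oc1=O` gives 10000 nM in an assay on mitochondria (strain Sprague-Dawley) for inhibition of Amine oxidase [flavin-containing] A (Rattus norvegicus), read by spectrophotometry; a higher number here means a weaker inhibitor, a lower number a stronger inhibitor.
Compound 2 `Cc1c(C)c2ccc(OCC(O)c3ccccc3)cc2oc1=O` gives 10000 nM in this assay.

Compound 2 stands level with compound 1 on these numbers. Going by the values given here, the one measured step, no change at the digits printed from compound 1 to compound 2 (within the scatter), rests on the fact that one of compounds 1 and 2 is drawn with a defined configuration and the other without, at the place where they differ and shows no change beyond the scatter. Compound 3 `Cc1c(C)c2ccc(OC[C@H](O)c3ccccc3)cc2oc1=O` differs from compound 2 by the two compounds have the same atoms and bonds; at least one stereo element is drawn with a configuration in one of them and without one in the other: 1 of 1 stereo elements differ; a stereocentre at a saturated chain carbon is drawn without a configuration in compound 2 and R in compound 3. The same kind of step, a change of drawn configuration only, therefore bears on it, and no shift beyond the scatter is expected in this assay. The expected step of no change at the digits printed from compound 2 to compound 3 (within the scatter) is flat. Compound 3 is estimated at 10000 nM, range 4000 nM to 25000 nM.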

Compound 3, half-maximal inhibitory concentration: 3240 nM
Compound 3: middle estimate off by 3.1-fold (0.49 log units), on the high side, outside the stated range (below it).
By their numbers in this assay, from the lowest: compound 3; then compounds 1 and 2 (each within the scatter of the next).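

In this assay, the stereocentre at the saturated chain carbon does register: the R drawing gives a 3.1-fold lower number from compound 1 to compound 3 (0.49 log units; beyond the scatter), and against the drawing without a configuration it gives a 3.1-fold lower number from compound 2 to compound 3 (0.49 log units; beyond the scatter). Compounds 1 and 2 alone gave no sign of this, since their step was flat. The shift can be set down to configuration alone: the fact that compounds 1 and 3 differ only in the configuration as drawn

Open, from the compounds shown here alone, is whether the R drawing keeps this edge when the hydroxyl gives way to an amine, or when a longer chain joins the stereocentre to the core.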